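A few compounds are considered here, and "the series" means these few. Any claim that something is new, unique, unknown or untested is made for them only; others in the source may bear on it.

Going by the values given here, only two compounds have numbers so far in a functional assay on HepG2 cells (Homo sapiens) for antiproliferative activity, read by MTT assay, with a stated time of 48 h; a lower number here means a stronger inhibitor, a higher number a weaker inhibitor. Compound 1 `O=C(/C=C/c1ccc(O)cc1)Nc1cc2c(Nc3ccc(Cl)c(Cl)c3)ncnc2s1` gives 42900 nM, the higher of the two, while compound 2 `N#Cc1cccc(Nc2ncnc3cc(NC(=O)/C=C/c4ccccc4)sc23)c1` gives 15900 nM, a gap beyond the usual scatter. Compound 3 `O=C(/C=C/c1ccccc1)Nc1cc2c(Nc3ccc(Cl)c(Cl)c3)ncnc2s1` is compound 1 with a single edit: hydrogen in place of hydroxy on an aromatic carbon, which turns 4-hydroxyphenyl into phenyl (hydrogen in place of hydroxy on an aromatic carbon). Among the compounds with values here, no measured pair shows this change alone, so any expectation rests on thin evidence. Compound 3 carries the same 2-phenylethenyl group as compound 2, and compound 2 gives 15900 nM, though the two also differ elsewhere. A modest fall in the number is therefore expected. The expected step is a 1.7-fold lower number from compound 1 to compound 3 (0.23 log units; within the scatter), a small one that may not clear the scatter. For compound 3 the estimated value is 25000 nM, with a range of 9000 nM to 60000 nM.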

Compound 3, half-maximal inhibitory concentration: 30100 nM
Estimate against measurement, compound 3: 1.2-fold (0.08 log units) below; the measured number falls inside the stated range.
By their numbers in this assay, from the lowest: compounds 2, 3 and 1 (each within the scatter of the next, the first and the last beyond it).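

Going by these compounds alone, compound 1 and compound 3 form the first pair that isolates this change, and replacing hydroxy with hydrogen on the aromatic carbon gives a 1.4-fold lower number from compound 1 to compound 3 (0.15 log units; within the scatter) in this assay. So 4-hydroxyphenyl and phenyl cannot be told apart at this position in this assay, and the hydrogen-bond donor and acceptor counted for the hydroxy leave no measurable mark on the number here. No measured information is available to explain this result.

From the compounds shown here alone, it remains open whether a different group at this position, such as an amine, a methoxy group or a carboxylic acid, would move the number beyond the scatter. It is also unknown whether adding a hydroxy to the phenyl of compound 2, which carries a nitrile elsewhere, would likewise make no clear difference.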